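The compounds below may be only part of what the source reports. "The series", "measured", "known", "first", "only" and "open" are said of these compounds alone.

Within the data shown here, compound 2 `O=C(OC1CCC(CN2CCN(c3cc(=O)c4cc(C(F)(F)F)cc([N+](=O)[O-])c4s3)CC2)CC1)C1CCCCC1` is the one compound here with a plain number: in an ADME assay on cells (Hepatocyte, Mus musculus) for metabolic stability (a higher number here means that the compound lasts longer, a lower number that the compound disappears faster), compound 2 gives 0.0783 h. Compound 1 `CC(=O)OC1CCC(CN2CCN(c3cc(=O)c4cc(C(F)(F)F)cc([N+](=O)[O-])c4s3)CC2)CC1` stands apart from it. In this assay compound 1 gives < 0.15 h, which is a limit of the assay rather than a number. Among the measured compounds shown here, the single measured step, a step that the limit leaves unreadable from compound 1 to compound 2, therefore cannot be read in size or direction because of the limit of < 0.15 h in this assay, at which 1 of the 2 values shown sits. Compound 3 `COc1ccc(C(=O)OC2CCC(CN3CCN(c4cc(=O)c5cc(C(F)(F)F)cc([N+](=O)[O-])c5s4)CC3)CC2)cc1` differs from compound 2 in one place: 4-methoxyphenyl in place of cyclohexyl on a carbonyl carbon. No readable step bears on this change, so there is no basis for expecting a shift beyond the usual scatter in either direction. Compound 3 is thus estimated to give 0.08 h in this assay, with a range from 0.03 h to 0.25 h. The expected step from compound 2 is a 1.0-fold higher number from compound 2 to compound 3 (0.01 log units; within the scatter), and the range is kept wide given how little the measured data show.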

Compound 3, half-life: 0.295 h
The estimate for compound 3 lay 3.7-fold (0.57 log units) below the measured number; the measured number lies above the stated range.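

In this assay, among these compounds, the group on the carbonyl carbon proves able to shift the result: 4-methoxyphenyl in place of cyclohexyl gives a 3.8-fold higher number from compound 2 to compound 3 (0.58 log units; beyond the scatter), the first readable step at this position. Among the compounds shown here, this is one pair, so it shows only that this aromatic ring outlasts the cyclohexyl ring here, not that aromatic rings generally do so. Set against methyl, the same group gives an at least 1.9-fold higher number from compound 1 to compound 3 (0.29 log units; that floor lies within the scatter), and this comparison yields only a floor because it rests on a limit: the limit of < 0.15 h in this assay, at which 1 of the 3 values shown sits.

The change swaps the ring type and adds a methoxy group at once, so the step cannot be assigned to either alone. A plain phenyl on the same carbonyl carbon would separate the two, while an amine on the 4-position of that ring would test whether the methoxy group can be replaced.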